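Working notes: a second methoxy on compound 2

The source may report more compounds than this note shows. Statements on the series, on what has been measured and on what is new or still open speak of the compounds shown alone.

Compound 1 `Cc1ccc(S(=O)(=O)NC(C)C2=CC(=O)c3c(O)ccc(O)c3C2=O)cc1` gives 30 nM in a functional assay on HL-60 cells (Homo sapiens) for cytotoxicity, read by MTT assay; a higher number here means a weaker inhibitor, a lower number a stronger inhibitor
Compound 2 `COc1ccc(S(=O)(=O)NC(C)C2=CC(=O)c3c(O)ccc(O)c3C2=O)cc1` gives 20 nM in this assay

Compound 2 stands within the scatter of compound 1, so the two values set no order. Compound 3 `COc1ccc(S(=O)(=O)NC(C)C2=CC(=O)c3c(O)ccc(O)c3C2=O)c(OC)c1` carries one further change from compound 2: methoxy in place of hydrogen on an aromatic carbon which reads as 4-methoxyphenyl to 2,4-dimethoxyphenyl. Among the compounds with values here, the only measured step is a 1.5-fold lower number from compound 1 to compound 2 (0.18 log units; within the scatter) and it stays within the scatter. That step puts methoxy in place of methyl, not hydrogen, so it bears only loosely on this change. Within the data shown here, no measured compound carries a group ortho to a large group on this ring. Expected is a 1.3-fold higher number from compound 2 to compound 3 (0.10 log units; within the scatter) in this assay with no move beyond the scatter in either direction, though on thin evidence. The value expected for compound 3 is 25 nM with an estimated range from 8 nM to 80 nM at this stage.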

Compound 3, half-maximal inhibitory concentration: 500 nM
Estimate against measurement, compound 3: 20-fold (1.30 log units) below; measured number above the stated range.
By their numbers in this assay, from the lowest: compounds 2 and 1 (each within the scatter of the next); then compound 3.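

In this assay methoxy in place of hydrogen, ortho to a large group, gives a 25-fold higher number from compound 2 to compound 3 (1.40 log units; beyond the scatter) and so marks this place on the ring as one where the series responds sharply. The earlier change of methoxy for methyl, a 1.5-fold lower number from compound 1 to compound 2 (0.18 log units; within the scatter), gave no such signal and set no order between its two compounds. The 2,4-dimethoxyphenyl compound also stands apart from the 4-methylphenyl compound, with a 17-fold higher number from compound 1 to compound 3 (1.22 log units; beyond the scatter), and no measurement at hand bears on the cause of the rise.

As far as these compounds go, whether the step belongs to methoxy in particular or would follow any group at this place stays open; a fluorine atom, a hydroxyl or an amine there would test this. From the compounds shown here alone, whether it depends on the methoxy already on the ring also stays open.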